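The source may report more compounds than this note shows. Statements on the series, on what has been measured and on what is new or still open speak of the compounds shown alone.

Measured compounds:
Compound 1, `Cc1ccc(CN(C)C(=O)c2nn(-c3ccc(F)cc3)c(OC[C@@H](O)C[C@@H](O)CC(=O)O)c2C(C)C)cc1`: 37 nM
Compound 2, `CC(C)c1c(C(=O)N2CCCC2c2ccccc2)nn(-c2ccc(F)cc2)c1OC[C@@H](O)C[C@@H](O)CC(=O)O`: 14 nM
Compound 3, `COc1ccc(CNC(=O)c2nn(-c3ccc(F)cc3)c(OC[C@@H](O)C[C@@H](O)CC(=O)O)c2C(C)C)cc1`: 12 nM

In an assay on microsomes from liver for inhibition of 3-hydroxy-3-methylglutaryl-coenzyme A reductase (Rattus norvegicus) (a higher number here means a weaker inhibitor, a lower number a stronger inhibitor), compound 3 has the lowest number of the three; the gap to compound 2 is within the scatter, while the step of a 3.1-fold lower number from compound 1 to compound 3 (0.49 log units; beyond the scatter) is beyond it.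

Compound 4, `Cc1cccc(CN(C)C(=O)c2nn(-c3ccc(F)cc3)c(OC[C@@H](O)C[C@@H](O)CC(=O)O)c2C(C)C)c1`, is not yet measured. It differs from compound 3 at one place: methyl(3-methylbenzyl)amino in place of (4-methoxybenzyl)amino on a carbonyl carbon. The amide thus returns to a methyl-bearing nitrogen with a methylbenzyl group, as in compound 1, whose methyl(4-methylbenzyl)amino differs from the entering group only in where the ring methyl sits. For the measured compounds named here, the only measured step bearing on this is a 3.1-fold lower number from compound 1 to compound 3 (0.49 log units; beyond the scatter), which ran the other way. Its reverse is therefore expected here, as a modest rise in the number, a 2.5-fold higher number from compound 3 to compound 4 (0.40 log units; beyond the scatter).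

The value of compound 4 in this assay is estimated at 30 nM, within 12 nM to 75 nM.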

Compound 4, half-maximal inhibitory concentration: 37 nM
Estimate against measurement, compound 4: 1.2-fold (0.09 log units) below; low and high end bracket the measured number.
By their numbers in this assay, from the lowest: compounds 3 and 2 (each within the scatter of the next); then compounds 1 and 4 (each within the scatter of the next).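

In this assay, 3-methylphenyl in place of 4-methylphenyl gives no change at the digits printed from compound 1 to compound 4 (within the scatter), so this shift of the ring methyl on the methylated amide leaves no readable mark. The methyl(3-methylbenzyl)amino amide also sits in the same relation to the other two amides as compound 1 does, with a 3.1-fold higher number from compound 3 to compound 4 (0.49 log units; beyond the scatter) and a 2.6-fold higher number from compound 2 to compound 4 (0.42 log units; beyond the scatter).

Still open, going by these compounds, is whether the methyl on the amide nitrogen or the ring group carries the gap to compound 3, and how a chlorophenyl or pyridyl ring would read on the same methylated amide. No measurement on hand explains these steps.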